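Aryl nitrile series: replacing fluoro with ethylsulfonyl

This account rests on a few compounds, and the source may have more. Where it says the series, first, only, none or still open, it means among the compounds named here.

Compound 1 `Cc1ccc2ccc(-c3ccc(C#N)cc3)cc2n1`: > 10000 nM
Compound 2 `Cc1ccc2ccc(-c3cc(F)cc(C#N)c3)cc2n1`: 0.8 nM

In a functional assay on CHO cells for inhibition of metabotropic glutamate receptor 5 (Rattus norvegicus), read by FLIPR and calcium flux (on this read-out higher numbers stand for weaker inhibition and lower numbers for stronger inhibition), compound 1 gives only a limit, > 10000 nM, not a number; this is the limit of > 10000 nM in this assay, at which 1 of the 2 values shown sits. In this assay compound 2 gives 0.8 nM, the only number shown for the series. For the measured compounds named here, compound 2 therefore stands as the sole measured point from which the next change can be judged, and no step between measured compounds is available to size it.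

Compound 3 `CCS(=O)(=O)c1cc(C#N)cc(-c2ccc3ccc(C)nc3c2)c1` differs from compound 2 by ethylsulfonyl in place of fluoro on an aromatic carbon. The ethylsulfonyl takes the position that the fluoro held, meta to the cyano group and meta to a large group. The group that enters brings more heavy atoms and two hydrogen-bond acceptors where the fluoro brought none, so a loss of inhibition beyond the scatter is expected rather than a gain. The step from compound 2 to compound 3 is estimated at a 38-fold higher number from compound 2 to compound 3 (1.57 log units; beyond the scatter). In this assay compound 3 is expected to give about 30 nM, with a range from 3 nM to 300 nM.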

Compound 3, half-maximal inhibitory concentration: 1090 nM
Estimate against measurement, compound 3: 36-fold (1.56 log units) below, and the stated range ends below it.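

In this assay, the place held by fluoro, meta to a cyano group and meta to a large group, proves sensitive to what stands on it: ethylsulfonyl in place of fluoro gives a 1400-fold higher number from compound 2 to compound 3 (3.13 log units; beyond the scatter). For the compounds shown here, this is the only sized step so far, and the value of compound 2 alone could not show that this position responds so strongly to a change of group. The change still leaves a measured number and not a limit for compound 3, so the position keeps some room for further reading of the series: the limit of > 10000 nM in this assay, at which 1 of the 3 values shown sits.

One pair cannot separate the contribution of the extra heavy atoms from that of the hydrogen-bond acceptors that enter with ethylsulfonyl, and it gives no cause for the step. Open as well is how chloro, methoxy, methylsulfonyl or an amine on the same aromatic carbon would read in this assay, and whether any group there would match or improve on fluoro.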